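The compounds below may be only part of what the source reports. "The series", "measured", "known", "first", "only" and "open" are said of these compounds alone.

Measured in an ADME assay on the whole organism (Mus musculus, strain CD1) for pharmacokinetics, read by LC-MS, with a stated time of 24 h, at a dose of 5 mg/kg by the oral route; on this read-out higher numbers stand for higher exposure at the dose given and lower numbers for lower exposure:
Compound 1 `O=C(O)Cn1nc(Cc2nc3cc(Cl)c(OCC(F)F)cc3[nH]2)c2ccccc2c1=O`: 55 ng.h/mL
Compound 2 `O=C(O)Cn1nc(Cc2cn3cc(OCC4CC4)c(Cl)cc3n2)c2ccccc2c1=O`: 798 ng.h/mL
Compound 3 `O=C(O)Cn1nc(Cn2cc3cc(OCC4CC4)c(Cl)cc3n2)c2ccccc2c1=O`: 2630 ng.h/mL

Of these three, compound 3 stands highest in this assay, at 2630 ng.h/mL. Compound 2 is the nearest, with 798 ng.h/mL, and compound 1 is the furthest, with 55 ng.h/mL. Both gaps lie beyond the scatter.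

The next compound is compound 4 `C[C@H](C(=O)O)n1nc(Cn2cc3cc(OCC4CC4)c(Cl)cc3n2)c2ccccc2c1=O`, which differs from compound 3 at a single place: methyl in place of hydrogen on a saturated chain carbon bound to an aromatic nitrogen and a carbonyl carbon. This puts methyl in place of hydrogen on a saturated chain carbon bound to an aromatic nitrogen and a carbonyl carbon, turning carboxymethyl into 1-carboxyethyl.

Among the compounds with values here, no measured pair shows this change, and the three measured compounds differ from one another in more than one place. The expectation therefore rests on compound 3 at 2630 ng.h/mL, and no step beyond the scatter is expected. From the compounds shown here alone, the estimate is a 1.1-fold higher number from compound 3 to compound 4 (0.06 log units; within the scatter), a small expected step whose direction remains open. For compound 4 the expected value is 3000 ng.h/mL, with an estimated range from 1000 ng.h/mL to 8000 ng.h/mL.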

Compound 4, area under the concentration-time curve: 5510 ng.h/mL
Estimate against measurement, compound 4: 1.8-fold (0.26 log units) below; low and high end bracket the measured number.
By their numbers in this assay, from the lowest: compound 1; then compound 2; then compound 3; then compound 4.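

In this assay, the saturated chain carbon bound to an aromatic nitrogen and a carbonyl carbon accepts a substituent without any loss of exposure: turning carboxymethyl into 1-carboxyethyl gives a 2.1-fold higher number from compound 3 to compound 4 (0.32 log units; beyond the scatter). Within the data shown here, this is the first comparison that isolates a single change, since the earlier compounds differ from one another in more than one place, and it shows that this one added methyl is enough to produce a modest step upward on the shared core. Nothing at hand bears on what lies behind this step.

From the compounds shown here alone, it remains open whether an ethyl group, a longer chain or two methyl groups on this same carbon would carry the step further, and how the opposite mirror-image arrangement at this carbon would compare. Going by these compounds, it is also open whether methyl at this place would produce a similar step on the cores of compound 1 and compound 2.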